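The source may report more compounds than this note shows. Statements on the series, on what has been measured and on what is new or still open speak of the compounds shown alone.

Measured so far in a functional assay on MCF7 cells (Homo sapiens); on this read-out lower numbers stand for stronger inhibition and higher numbers for weaker inhibition:
compound 1 `COc1cc(NC(C)CCCNC(=O)NCCO)c2ncccc2c1` gives 25000 nM
compound 2 `COc1cc(NC(C)CCCNC(=O)NOCc2ccccc2)c2ncccc2c1` gives 9000 nM
compound 3 `COc1cc(NC(C)CCCNC(=O)NC(CO)(CO)CO)c2ncccc2c1` gives 24000 nM

Compound 3 at 24000 nM lies within the scatter of compound 1, and the two stand at the high end of the three numbers. The gap to the benzyloxy compound is a 2.7-fold higher number from compound 2 to compound 3 (0.43 log units; beyond the scatter) and counts as modest.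

The next compound is compound 4 `COc1cc(NC(C)CCCNC(=O)N(CCO)CCO)c2ncccc2c1` with bis(2-hydroxyethyl)amino in place of (2-hydroxy-1,1-bis(hydroxymethyl)ethyl)amino on a carbonyl carbon as its change: bis(2-hydroxyethyl)amino in place of (2-hydroxy-1,1-bis(hydroxymethyl)ethyl)amino on a carbonyl carbon. The nearest evidence is a 1.0-fold lower number from compound 1 to compound 3 (0.02 log units; within the scatter) for one hydroxy-bearing group exchanged for another. The other step from compound 1 is a 2.8-fold lower number from compound 1 to compound 2 (0.44 log units; beyond the scatter) and is also modest, but it brings in benzyloxy, which compound 4 lacks. Among the measured compounds shown here, no measured compound carries the entering group itself, so the range stays wide. In this assay the expected step is a 1.1-fold lower number from compound 3 to compound 4 (0.04 log units; within the scatter) and so none beyond the scatter. For compound 4 the estimate is 22000 nM with 10000 nM to 50000 nM as the expected range.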

Compound 4, half-maximal inhibitory concentration: 36000 nM
Compound 4: the middle estimate sits 1.6-fold (0.21 log units) below what was measured, and the stated range covers the measured number.
By their numbers in this assay, from the lowest: compound 2; then compounds 3, 1 and 4 (each within the scatter of the next).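

Compound 4 is the first compound shown with no hydrogen left on the amide-type nitrogen, and in this assay replacing that hydrogen with 2-hydroxyethyl gives a 1.4-fold higher number from compound 1 to compound 4 (0.16 log units; within the scatter), so the change does not move the number beyond the scatter. Bis(2-hydroxyethyl)amino in place of (2-hydroxy-1,1-bis(hydroxymethyl)ethyl)amino on the carbonyl carbon gives a 1.5-fold higher number from compound 3 to compound 4 (0.18 log units; within the scatter), while the step from the benzyloxy compound gives a 4.0-fold higher number from compound 2 to compound 4 (0.60 log units; beyond the scatter), which leaves compound 2 as the only compound set apart from the three hydroxy-bearing compounds. Nothing available accounts for these numbers.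

Still open, going by these compounds, is how a morpholine or piperazine ring on the carbonyl carbon would read in this assay. Also open, on these data alone, is whether the lower number of compound 2 follows the phenyl ring or the oxygen on the amide-type nitrogen, which benzylamino on the carbonyl carbon would help separate.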